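A few compounds are considered here, and "the series" means these few. Any claim that something is new, unique, unknown or untested is made for them only; others in the source may bear on it.

Two compounds give the starting point. Compound 1, `CC[C@H](C)[C@H](N)CN(C(=O)[C@@H]1C[C@H]1c1ccccc1F)c1ccc(-c2ccccc2)cc1`, was tested in a functional assay for agonist activity at G protein-coupled receptor 88 (Homo sapiens), read by HTRF and cAMP accumulation (a higher number here means that more compound is needed for the effect, a lower number that less compound is needed), and compound 1 gives 650 nM. Compound 2, `CC(C)C[C@H](N)CN(C(=O)[C@@H]1C[C@H]1c1ccccc1)c1ccc(-c2ccsc2)cc1`, gives 1200 nM in this assay. Compound 2 has the higher of the two numbers, but its nearest neighbour, compound 1, sits within the scatter of repeated measurements, so the two values cannot be told apart with confidence and neither compound can be called the more potent one.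

The next step leads to compound 3, `Cc1cccc(-c2ccc(N(C[C@@H](N)CC(C)C)C(=O)[C@@H]3C[C@H]3c3ccccc3)cc2)c1`. Compound 3 differs from compound 2 in one place: 3-methylphenyl in place of thiophen-3-yl on an aromatic carbon. Going by the values given here, no step between measured compounds speaks to this change, so there is nothing to learn from in the numbers. Compound 3 is therefore expected to land close to compound 2, with the step of a 1.5-fold lower number from compound 2 to compound 3 (0.18 log units; within the scatter) in this assay amounting to little more than the usual scatter, if anything slightly towards a lower number. Compound 3 is expected to give about 800 nM, most likely between 300 nM and 2500 nM, in this assay.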

Compound 3, half-maximal effective concentration: 1200 nM
Compound 3: middle estimate off by 1.5-fold (0.18 log units), on the low side; measured number inside the range.
By their numbers in this assay, from the lowest: compounds 1, 2 and 3 (each within the scatter of the next).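

Going by these compounds alone, on an aromatic carbon para to a large group, putting 3-methylphenyl in place of thiophen-3-yl brings no change at the digits printed from compound 2 to compound 3 (within the scatter) in this assay, the first direct reading of a change at this position. The position therefore takes a six-membered aromatic ring of carbon only, with its added methyl, as well as a five-membered aromatic ring with 1 hetero atom, even though the swap adds heavy atoms and removes the sulfur and the hydrogen-bond acceptor counted for thiophen-3-yl. Nothing measured here accounts for this flat result.

Compound 1 carries a plain phenyl at this position but also differs from compound 2 and compound 3 elsewhere, so it cannot show what the methyl contributes. The compounds shown also leave open whether the number would hold with a different kind of group on this ring, such as an amine, a carboxylic acid or a pyridine in place of the aromatic rings seen so far.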